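Sulfur for oxygen on the diaryl ether of compound 1

The source may hold more compounds than are shown below. What is called first, only, known or untested is meant among the compounds shown, and "the series" means these compounds.

Working notes on the series. In a functional assay on NCI-H23 cells (Homo sapiens) for inhibition, read by sulforhodamine B assay, with a stated time of 48 h (a higher number here means that more compound is tolerated, a lower number that less compound is tolerated), compound 1 `Nc1cc(N)c2nc(-c3ccccc3)c(Oc3ccc(Cl)c(Cl)c3)nc2c1` returns only < 100000 nM, which is a limit of the assay and not a measured number. Compound 2 `CCOC(=O)[C@H](CCC(=O)O)NC(=O)c1ccc(CNc2nc3cc(N)cc(N)c3nc2-c2ccccc2)cc1` likewise returns only < 100000 nM, again a limit rather than a number. Among the compounds with values here, compound 3 `COc1ccc(CNc2nc3cc(N)cc(N)c3nc2-c2ccccc2)cc1` is the one member with a measured value, giving 70800 nM in this assay. Compound 1 therefore stands only as a limit among the values shown, and the common ground of the set is the limit of < 100000 nM in this assay, at which 2 of the 3 values shown sit. Within the data shown here, no step between two measured compounds can be computed here, so the size of any change away from compound 1 is not known from the data themselves.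

Compound 4 `Nc1cc(N)c2nc(-c3ccccc3)c(Sc3ccc(Cl)c(Cl)c3)nc2c1` remains to be measured. It differs from compound 1 by (3,4-dichlorophenyl)sulfanyl in place of 3,4-dichlorophenoxy on an aromatic carbon. Since compound 1 shows only the limit < 100000 nM, no step beyond the scatter in either direction is expected from this exchange. Compound 4 is expected to give about 60000 nM in this assay, with a likely range from 20000 nM to 200000 nM. The expected step that the limit leaves unreadable from compound 1 to compound 4 is thus taken as none beyond the scatter, with a fair chance that only a limit is reported again.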

Compound 4, concentration lethal to 50% of the cells: 95500 nM
Beside the measured number, compound 4's estimate is 1.6-fold (0.20 log units) below it, within the range that was stated.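

No step can be read from compound 1 to compound 4, because compound 1 stands only at a limit of the assay and not at a number: the limit of < 100000 nM in this assay, at which 2 of the 4 values shown sit.

The compounds shown leave open whether (3,4-dichlorophenyl)sulfanyl in place of 3,4-dichlorophenoxy on the shared core changes the read-out in this assay at all.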